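The compounds below may be only part of what the source reports. "The series", "measured", "known", "first", "only" and "open" are said of these compounds alone.

Compound 1, `COC1=C(OC)[C@H](OC(C)=O)[C@H](C/C=C(\C)CC/C=C(\C)C[C@H](O)/C=C(\C)CO)[C@@H](C)C1=O`, gives in a functional assay on PC-3 cells (Homo sapiens) for inhibition, read by sulforhodamine B assay, with a stated time of 48 h; on this read-out higher numbers stand for weaker inhibition of growth and lower numbers for stronger inhibition of growth > 30000 nM, which is a limit of the assay and not a number.
Compound 2, `COC1=C(OC)[C@H](OC(C)=O)[C@H](C/C=C(\C)CC/C=C(\C)C[C@H](O)C[C@@H](C)C(O)O)[C@@H](C)C1=O`, gives in this assay > 30000 nM, also a limit.
Compound 3, `COC1=C(OC)[C@H](OC(C)=O)[C@H](C/C=C(\C)CC/C=C(\C)C[C@H](O)C=C(C)C)[C@@H](C)C1=O`, gives in this assay > 30000 nM, again a limit.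

Compound 3 therefore has no place on a scale: its result is only a limit, and the limit of > 30000 nM in this assay, at which 3 of the 3 values shown sit, shows that every value in this set rests at that same limit. The three measured steps, a step that the two limits leave unreadable from compound 1 to compound 2, a step that the two limits leave unreadable from compound 1 to compound 3 and a step that the two limits leave unreadable from compound 2 to compound 3, carry no readable size for the same reason, so none of them tells how a change at the end of the side chain moves the growth inhibition.

Compound 4, `COC1=C(OC)[C@H](OC(C)=O)[C@H](C/C=C(\C)CC/C=C(\C)C[C@H](O)/C=C(\C)C(=O)O)[C@@H](C)C1=O`, differs from compound 3 by 2-carboxyprop-1-en-1-yl in place of 2-methylprop-1-en-1-yl on a saturated chain carbon bound to an oxygen on a saturated carbon and a saturated chain carbon. Among the compounds with values here, the change sits at the same place as the two unreadable steps that end in compound 3, and no measured step speaks to it. In this assay compound 4 is therefore expected to return once more a limit rather than a number, and the step that the limit leaves unreadable from compound 3 to compound 4 is expected to be unreadable in size. Compound 4 is estimated at 40000 nM, with a range from 15000 nM to 120000 nM.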

Compound 4, concentration for 50% growth inhibition: > 30000 nM
Compound 4: only a limit was reported (the forecaster's own chance of this, stated with the estimate: 80%); the middle value does not contradict the limit.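

Compound 4, like compound 1, compound 2 and compound 3, returns only a limit in this assay, so no step among these compounds can be read: the limit of > 30000 nM in this assay, at which 4 of the 4 values shown sit.

The compounds shown leave open how any of these changes at the end of the side chain moves the inhibition of growth, and whether any such change can do so at all.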